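This account rests on a few compounds, and the source may have more. Where it says the series, first, only, none or still open, it means among the compounds named here.

Of the compounds shown here, three of one shared core have been measured in an assay on CCRF-CEM cells for displacement of a labelled ligand from C-X-C chemokine receptor type 4 (Homo sapiens); on this read-out lower numbers stand for stronger inhibition and higher numbers for weaker inhibition. Compound 1 `CN(/C(=N/C1CCCCC1)SCC1=CSC2=NCCN12)C1CCCCC1` gives 3580 nM, which is the second highest of the three numbers. Compound 2 `C1=C(CS/C(=N\C2CCCC2)NC2CCCC2)N2CCN=C2S1` gives 3840 nM, a number within the scatter of that of compound 1. Compound 3 `CC(C)(C)C1CCC(N/C(=N/C2CCCCC2)SCC2=CSC3=NCCN23)CC1` gives 1530 nM, the lowest number and beyond the scatter below compound 1.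

Compound 4 `C1=C(CS/C(=N\C2CCCCC2)Nc2ccccc2)N2CCN=C2S1` is not yet measured. It differs from compound 1 by one change: anilino in place of cyclohexyl(methyl)amino on a carbon with a double bond to nitrogen. For the measured compounds named here, the measured compounds show no step that isolates this kind of change, since compound 2 alters the ring size and the methyl together. The step from compound 1 to compound 4 is therefore expected to be small, a 1.1-fold higher number from compound 1 to compound 4 (0.05 log units; within the scatter), with no clear direction beyond the scatter. For compound 4 in this assay the estimate is 4000 nM, within a range from 1500 nM to 11000 nM.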

Compound 4, half-maximal inhibitory concentration: > 10000 nM
Compound 4: no number, only a limit (the forecaster's own chance of this, stated with the estimate: 10%); middle value at least 2.5-fold (0.39 log units) from the limit.
By their numbers in this assay, from the lowest: compound 3; then compounds 1 and 2 (each within the scatter of the next). At a limit, above all of these: compound 4.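

In this assay, for the compounds shown here, this is the first step that isolates one change on this carbon: anilino in place of cyclohexyl(methyl)amino gives an at least 2.7-fold higher number from compound 1 to compound 4 (0.44 log units; beyond the scatter). The position is therefore not indifferent to the group it carries, and this swap weakens inhibition beyond the scatter. For compound 4, > 10000 nM is a limit, not a number: the limit of > 10000 nM in this assay, at which 1 of the 4 values shown sits.

The compounds shown do not separate the effect of the aromatic ring from that of the hydrogen on the nitrogen. On these data alone, what a methyl(phenyl)amino group on this carbon would give, with the ring kept and that hydrogen gone, remains open.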